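The compounds below may be only part of what the source reports. "The series", "measured", "known", "first", "only" and "open" are said of these compounds alone.

Working notes on the series. Compound 1 `Cc1nc(C)c([C@H](OC(C)(C)C)C(=O)O)c(N2CCC(C)(C)CC2)c1-c1ccc(SCCc2ccc(F)cc2)cc1` is the parent of this pair. In an ADME assay on microsomes from liver (Rattus norvegicus) for metabolic stability, read by LC-MS, tested at 0.5 uM (on this read-out lower numbers stand for a shorter-lived compound and higher numbers for a longer-lived compound), compound 1 reaches only the limit > 2 h, not a number, so the read-out is the limit of > 2 h in this assay, at which 1 of the 2 values shown sits. Compound 2 `Cc1nc(C)c([C@H](OC(C)(C)C)C(=O)O)c(N2CCC(C)(C)CC2)c1-c1ccc(OCCc2ccccn2)cc1` carries 2-(pyridin-2-yl)ethoxy in place of (2-(4-fluorophenyl)ethyl)sulfanyl on an aromatic carbon; in this assay compound 2 gives 1.02 h. The step is an at least 1.9-fold lower number from compound 1 to compound 2 (0.29 log units; that floor lies within the scatter). For the measured compounds named here, compound 2 therefore holds the only number in this assay; the other value is a limit.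

Compound 3 `Cc1nc(CCOc2ccc(-c3c(C)nc(C)c([C@H](OC(C)(C)C)C(=O)O)c3N3CCC(C)(C)CC3)cc2)cs1` follows from compound 2 by 2-methyl-1,3-thiazol-4-yl in place of pyridin-2-yl on a saturated chain carbon, two bonds along the chain from an oxygen on an aromatic ring. Going by the values given here, the only measured step, an at least 1.9-fold lower number from compound 1 to compound 2 (0.29 log units; that floor lies within the scatter), swaps the whole side chain and its linking atom, not just the terminal ring, and its floor lies within the scatter; it gives no direction for a ring swap at the chain end. No step beyond the scatter is expected in this assay for compound 3, with a 1.0-fold lower number from compound 2 to compound 3 (0.01 log units; within the scatter). Compound 3 is estimated at 1 h, range 0.5 h to 2.2 h.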

Compound 3, half-life: 1.75 h
Beside the measured number, compound 3's estimate is 1.8-fold (0.24 log units) below it; measured number inside the range.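

In this assay, for the compounds shown here, the ring at the end of the chain is changed on its own here for the first time, and 2-methyl-1,3-thiazol-4-yl in place of pyridin-2-yl gives a 1.7-fold higher number from compound 2 to compound 3 (0.23 log units; within the scatter), so this measurement does not separate the two rings at this position. Against the parent, the whole side-chain change gives an at least 1.1-fold lower number from compound 1 to compound 3 (0.05 log units; that floor lies within the scatter), a floor that also leaves compound 3 unseparated from compound 1. The value of compound 1 is a limit and not a number: the limit of > 2 h in this assay, at which 1 of the 3 values shown sits.

No pair among the compounds shown differs in the linking oxygen or sulfur alone, so the contribution of that atom in this assay cannot be separated from that of the terminal ring. As far as these compounds go, it also remains open how this position would respond to a larger change at the chain end, such as a terminal piperidine or a carboxylic acid on the ring, or to a longer chain between the oxygen and the ring.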